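Hydroxymethyl step in a series at the assay limit

The source may report more compounds than this note shows. Statements on the series, on what has been measured and on what is new or still open speak of the compounds shown alone.

Measured in a functional assay on BV-2 cells (Mus musculus) for inhibition, read by Griess assay, with a stated time of 24 h; on this read-out lower numbers stand for stronger inhibition and higher numbers for weaker inhibition:
- compound 1 `C=CCc1ccc(OC)c(-c2cc(CCC)on2)c1`: > 200000 nM (a limit)
- compound 2 `C=CCc1ccc(OC)c(-c2cc(CO)on2)c1`: > 200000 nM (a limit)
- compound 3 `C=CCc1ccc(O)c(-c2cc(CCC)on2)c1`: > 200000 nM (a limit)

Compound 3 gives > 200000 nM, which is a limit and not a number. The series stands at the limit of > 200000 nM in this assay, at which 3 of the 3 values shown sit, so no order among the three compounds can be read.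

Compound 4 `C=CCc1ccc(O)c(-c2cc(CO)on2)c1` differs from compound 3 by one change: hydroxy in place of ethyl on a saturated chain carbon bound to an aromatic carbon. This is propyl to hydroxymethyl.

The same change has been measured once, as a step that the two limits leave unreadable from compound 1 to compound 2. The other measured change, a step that the two limits leave unreadable from compound 1 to compound 3, is made at a different place. Neither step has a readable size, so neither supplies a size or direction to carry over.

Given a step that the two limits leave unreadable from compound 1 to compound 2, no step beyond the scatter is expected in this assay, and another limit is the likeliest report. The expected step is a number no higher from compound 3 to compound 4 (the limit leaves the size open). The estimated value for compound 4 is 200000 nM, with an expected range from 80000 nM to 400000 nM.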

Compound 4, half-maximal inhibitory concentration: > 200000 nM
Compound 4: only a limit was reported; the forecaster's own chance of this, stated with the estimate: 80%; the middle value sits exactly at the limit.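

In this assay, among the compounds shown here, compound 4 gives > 200000 nM, a limit and not a number, so no step linking it to compound 2 or compound 3 can be read. The compounds shown leave open any order among compounds 1 to 4, and whether propyl to hydroxymethyl changes inhibition at all: the limit of > 200000 nM in this assay, at which 4 of the 4 values shown sit.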